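Swapping Acetoxymethyl for Isopropyl in a Nitrophenyl Enone

The source may report more compounds than this note shows. Statements on the series, on what has been measured and on what is new or still open speak of the compounds shown alone.

Measured compounds:
Compound 1, `COc1ccc(C(=O)/C(=C/c2ccc(Cl)cc2Cl)CCOC(C)=O)cc1` — 34800 nM
Compound 2, `COc1ccc(C(=O)/C(=C/c2ccc([N+](=O)[O-])cc2)CCOC(C)=O)cc1` — > 100000 nM (a limit of the assay, not a number)
Compound 3, `COc1ccc(C(=O)/C(=C/c2ccc(Cl)cc2Cl)CC(C)C)cc1` — 14600 nM

All three compounds share one core and were tested in a functional assay on NB-4 cells (Homo sapiens) for inhibition, read by XTT assay, with a stated time of 48 h; on this read-out higher numbers stand for weaker inhibition and lower numbers for stronger inhibition. In this assay compound 1 gives 34800 nM. Compound 3 gives 14600 nM. For compound 2 the assay reports only a limit, > 100000 nM.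

Compound 2 differs from compound 1 by 4-nitrophenyl in place of 2,4-dichlorophenyl on a double-bonded chain carbon bound to a double-bonded chain carbon. This change gave an at least 2.8-fold higher number from compound 1 to compound 2 (0.45 log units; beyond the scatter), though the step rests on the limit of > 100000 nM in this assay, at which 1 of the 3 values shown sits, and so its true size is open.

Compound 3 differs from compound 1 by isopropyl in place of acetoxymethyl on a saturated chain carbon bound to a double-bonded chain carbon. That change gave a 2.4-fold lower number from compound 1 to compound 3 (0.38 log units; beyond the scatter).

The unmeasured compound 4, `COc1ccc(C(=O)/C(=C/c2ccc([N+](=O)[O-])cc2)CC(C)C)cc1`, carries the same kind of change relative to compound 2: isopropyl in place of acetoxymethyl on a saturated chain carbon bound to a double-bonded chain carbon. The place is described in the same words for both pairs.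

Because a 2.4-fold lower number from compound 1 to compound 3 (0.38 log units; beyond the scatter) was modest, a step of similar size is expected from compound 2 to compound 4. The expected step is an at least 1.2-fold lower number from compound 2 to compound 4 (0.09 log units; that floor lies within the scatter). Since the starting value of compound 2 is only a limit, the expected number for compound 4 is uncertain and may itself fall at the limit. Compound 4 is expected to give about 80000 nM, within a range from 30000 nM to 250000 nM.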

Compound 4, half-maximal inhibitory concentration: 600 nM
Compound 4: the middle estimate sits 130-fold (2.12 log units) above what was measured; the measured number lies below the stated range.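

In this assay, isopropyl in place of acetoxymethyl gave an at least 160-fold lower number from compound 2 to compound 4 (2.22 log units; beyond the scatter). The direction of this change carried from one core to the other, but its size did not: the same change on two cores in this assay, a 2.4-fold lower number (0.38 log units; beyond the scatter) from compound 1 to compound 3 and an at least 160-fold lower number (2.22 log units; beyond the scatter) from compound 2 to compound 4, at least 69-fold (1.84 log units) apart, beyond the scatter of two such steps. Compound 2 gives only a limit of the assay, > 100000 nM, so the true size of its step stays open, and two pairs of compounds cannot show why the step differs so much or predict its size on a further core.

The series shown holds only 2,4-dichlorophenyl and 4-nitrophenyl as the changing ring group, so it remains open whether the large step belongs to the 4-nitrophenyl core alone or would also appear with other groups there. As far as these compounds go, it also remains open how an amine, a carboxylic acid or a longer chain in place of isopropyl would read out on either core, which leaves isopropyl as the only replacement for acetoxymethyl that can be judged here.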